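The source may report more compounds than this note shows. Statements on the series, on what has been measured and on what is new or still open speak of the compounds shown alone.

Working notes on the series. The shared core of compound 1 `COc1cc(N(CC2CC2)c2ccccc2)cnc1C(=O)[C@H]1C[C@@H]1C(=O)O` carries an unsubstituted phenyl on the aryl-amine nitrogen; in an assay on isolated protein for inhibition of leukotriene C4 synthase (Homo sapiens), read by LC-MS, with stated times of 45 min and 20 min (a lower number here means a stronger inhibitor, a higher number a weaker inhibitor), compound 1 gives 1640 nM. Compound 2 `COc1cc(N(CC2CC2)c2cccc(C(F)(F)F)c2)cnc1C(=O)[C@H]1C[C@@H]1C(=O)O` gives 52.4 nM, and compound 3 `COc1cc(N(CC2CC2)c2cc(C(F)(F)F)ccc2F)cnc1C(=O)[C@H]1C[C@@H]1C(=O)O` gives 14 nM. Among the three numbers measured, compound 2 stands second highest: the nearest is compound 3 and the furthest is compound 1. The two measured steps both act on the same phenyl ring: a 31-fold lower number from compound 1 to compound 2 (1.50 log units; beyond the scatter), a large step, and a 3.7-fold lower number from compound 2 to compound 3 (0.57 log units; beyond the scatter), a modest one.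

Compound 4 `COc1cc(N(CC2CC2)c2cc(Cl)c(F)cc2F)cnc1C(=O)[C@H]1C[C@@H]1C(=O)O` is the next variation on that ring. Relative to compound 2 the change is 5-chloro-2,4-difluorophenyl in place of 3-(trifluoromethyl)phenyl on a nitrogen on an aromatic ring. Within the data shown here, no measured pair isolates the exchange of trifluoromethyl for chloro; the only direct bearing is a 3.7-fold lower number from compound 2 to compound 3 (0.57 log units; beyond the scatter), which shows that an added fluoro on this ring gave a modest lower number. Compound 4 carries two fluoro and a chloro in place of the trifluoromethyl of compound 2, so a modest step to a lower number is expected, about a 2.1-fold lower number from compound 2 to compound 4 (0.32 log units; beyond the scatter). Compound 4 is therefore estimated at 25 nM, within 8 nM to 80 nM.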

Compound 4, half-maximal inhibitory concentration: 27.6 nM
Beside the measured number, compound 4's estimate is 1.1-fold (0.04 log units) below it, and the stated range covers the measured number.
By their numbers in this assay, from the lowest: compounds 3, 4 and 2 (each within the scatter of the next, the first and the last beyond it); then compound 1.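

In this assay, 5-chloro-2,4-difluorophenyl in place of 3-(trifluoromethyl)phenyl on the nitrogen gives a 1.9-fold lower number from compound 2 to compound 4 (0.28 log units; within the scatter), so compound 2 and compound 4 cannot be told apart at this position. Against the unsubstituted phenyl the same change gives a 59-fold lower number from compound 1 to compound 4 (1.77 log units; beyond the scatter), which shows that a large step at this position does not need the trifluoromethyl carried by compound 2 and compound 3. The data at hand offer no independent measurement that accounts for either step.

The compounds shown do not separate the contributions of the chloro and the two fluoro groups, as these arrive together in compound 4. From the compounds shown here alone, how this ring would respond to a nitrile or an amine also remains open, as does the effect of a longer chain on the same nitrogen.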